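Anticonvulsant-type series: dose notes on the piperazine amide pair

The compounds below may be only part of what the source reports. "The series", "measured", "known", "first", "only" and "open" are said of these compounds alone.

Measured so far:
compound 1 `CC1(c2ccccc2)CC(=O)N(CC(=O)N2CCC(Cc3ccccc3)CC2)C1=O`: 100 mg/kg
compound 2 `CC1(c2ccccc2)CC(=O)N(CC(=O)N2CCN(c3ccccc3)CC2)C1=O`: 100 mg/kg

Both values come from a functional assay on the whole organism (strain CD-1) with Mus musculus as the target, with a stated time of 0.5 h; a lower number here means that less compound is needed, a higher number that more compound is needed for the effect. In this assay compound 1 gives 100 mg/kg and compound 2 gives 100 mg/kg; the two stand level at the digits shown, within the scatter, so the numbers say nothing about one being preferred over the other.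

Compound 3 `CC1(c2ccccc2)CC(=O)N(CC(=O)N2CCN(c3ccc(Cl)c(Cl)c3)CC2)C1=O` is not yet measured. It differs from compound 2 in one place: 3,4-dichlorophenyl in place of phenyl on an amine nitrogen in a ring. Going by the values given here, no measured step of this kind exists, so nothing in the data points in either direction. A step within the scatter, or none, is expected: no change at the digits printed from compound 2 to compound 3 (within the scatter). Compound 3 is therefore estimated at 100 mg/kg, with a range from 30 mg/kg to 300 mg/kg.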

Compound 3, minimum effective dose: "not active" (no number reported)
Nothing numeric was reported for compound 3; no gap can be computed for the estimate.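

Going by these compounds alone, compound 3 is reported as "not active" (no number reported), without a number, so no step from compound 2 to compound 3 can be read. The compounds shown leave open what dose, if any, goes with 3,4-dichlorophenyl in place of phenyl, and no evidence at hand bears on this result.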